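The source may hold more compounds than are shown below. What is called first, only, known or untested is meant among the compounds shown, and "the series" means these compounds.

In an ADME assay on CHO cells (Cricetulus griseus) for cytotoxicity, read by MTT assay (on this read-out lower numbers stand for stronger inhibition and higher numbers for weaker inhibition), compound 1 `Cc1ccc([C@H](NCC(C)C)[C@H](CO)OCc2ccccc2)cc1` gives 144000 nM and compound 2 `CCCN[C@@H](c1ccc(C)cc1)[C@H](CO)Oc1ccccc1` gives 326000 nM as the higher of the two numbers, which places compound 2 on the weaker side of this pair by a gap beyond the usual scatter. Compound 3 `CCCN[C@@H](c1ccc(OC)cc1)[C@H](CO)Oc1ccccc1` differs from compound 2 in one place (methoxy in place of methyl on an aromatic carbon), with methoxy in place of methyl on an aromatic carbon. Among the measured compounds shown here, no measured pair shows this change, so no shift beyond the scatter is expected, and no firm direction either. The expected step (a 1.1-fold lower number from compound 2 to compound 3 (0.04 log units; within the scatter)) is therefore small. In this assay compound 3 is estimated at 300000 nM (expected range 130000 nM to 650000 nM).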

Compound 3, half-maximal inhibitory concentration: 145000 nM
Beside the measured number, compound 3's estimate is 2.1-fold (0.32 log units) above it, within the range that was stated.
By their numbers in this assay, from the lowest: compounds 1 and 3 (each within the scatter of the next); then compound 2.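

Swapping methyl for methoxy on an aromatic carbon, para to a large group, gives a 2.2-fold lower number from compound 2 to compound 3 (0.35 log units; beyond the scatter) in this assay. This modest step shows that the number responds to a change at this position, moving toward stronger inhibition when one oxygen is added there. Nothing measured here explains why the number moves. As far as these compounds go, whether an ethoxy group or a chlorine atom at the same place would move the number further remains open. So does whether the step would hold with a butyl chain on the nitrogen.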